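The source may report more compounds than this note shows. Statements on the series, on what has been measured and on what is new or still open speak of the compounds shown alone.

Measured compounds, read in a functional assay on PC-12 cells (Rattus norvegicus) for cytotoxicity, read by MTT assay, with stated times of 3 h and 2 h, tested at 10 uM; on this read-out lower numbers stand for a weaker effect and higher numbers for a stronger effect at the one concentration tested:
compound 1, `Cc1cc(=O)oc2cc(OCCCn3cc(CNC(=O)CCCCC4CCSS4)nn3)ccc12`, gives 69.4%
compound 2, `O=C(CCCCC1CCSS1)NCc1cn(CCCCOc2ccc3ccc(=O)oc3c2)nn1`, gives 65.1%
compound 3, `O=C(CCCCC1CCSS1)NCc1cn(CCCCOc2ccc3cc(-c4ccccc4)c(=O)oc3c2)nn1`, gives 30.5%

Compound 3 stands lowest of the three numbers in this assay; the nearest is compound 2 and the furthest is compound 1, both standing above it beyond the scatter. For the measured compounds named here, the only single-point step in the set is a number 34.6 percentage points lower from compound 2 to compound 3 (beyond the scatter), a large one. Compound 4, `O=C(CCCCC1CCSS1)NCc1cn(CCCCOc2ccc3cc(-c4ccc(Cl)c(Cl)c4)c(=O)oc3c2)nn1`, differs from compound 3 by 3,4-dichlorophenyl in place of phenyl on an aromatic carbon. That step from compound 2 to compound 3 concerns the entry of the phenyl itself, not its substitution, so it bears on the present change only loosely. Going by the values given here, nothing measured shows what the two chlorines on that ring do, and no other compound in the set carries a substituted phenyl at this place. Among the compounds with values here, with no comparable step in hand, the expectation for this assay is a shift of modest size or none beyond the scatter, with no firm direction. The step expected from compound 3 to compound 4 is a number 1.5 percentage points higher from compound 3 to compound 4 (within the scatter). Compound 4 is accordingly estimated at 32%, with a range from 14% to 52%.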

Compound 4, a percentage reported as activity, at one concentration (the size of the read-out at that concentration, not a potency): 58.9%
Estimate against measurement, compound 4: 26.9 percentage points below; measured number outside the range, above it.
By their numbers in this assay, from the lowest: compound 3; then compounds 4, 2 and 1 (each within the scatter of the next, the first and the last beyond it).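

In this assay the change from phenyl to 3,4-dichlorophenyl on this aromatic carbon gives a number 28.4 percentage points higher from compound 3 to compound 4 (beyond the scatter) and so shows that the read-out at this place depends on what the phenyl ring carries, which compounds 2 and 3 alone could not show. Set against hydrogen at the same carbon, 3,4-dichlorophenyl gives a number 6.2 percentage points lower from compound 2 to compound 4 (within the scatter) while phenyl gives a number 34.6 percentage points lower from compound 2 to compound 3 (beyond the scatter) so the large step seen with compound 3 does not follow from placing just any substituted or unsubstituted phenyl ring here. Among the three groups shown at this carbon, unsubstituted phenyl alone stands apart, and hydrogen and 3,4-dichlorophenyl cannot be told apart in this read-out.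

Open remain whether a single chlorine would be enough, as in 3-chlorophenyl or 4-chlorophenyl, and what a methoxy group, an amine or a carboxylic acid on the phenyl ring would give at the same place. The compounds shown also hold no data that would give a reason for the difference between phenyl and 3,4-dichlorophenyl.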